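Series notes: nitro replaced by hydrogen on compound 2

A few compounds are considered here, and "the series" means these few. Any claim that something is new, unique, unknown or untested is made for them only; others in the source may bear on it.

Of the compounds shown here, three have been measured in an in vitro functional assay on 1321-N1 cells for agonist activity at Free fatty acid receptor 1 (Homo sapiens), read by fluorescence, spectrophotometry and calcium flux; on this read-out higher numbers stand for larger maximal responses and lower numbers for smaller maximal responses. Compound 1 `Cc1cc(C#Cc2ccc(CCC(=O)O)cc2)nc(Cl)n1` gives 110%, compound 3 `O=C(O)CCc1ccc(C#Cc2ccnc3cc(Cl)ccc23)cc1` gives 125%, and compound 2 `O=C(O)CCc1ccc(C#Cc2ncccc2[N+](=O)[O-])cc1` gives 87%, the lowest of the three; its gap to compound 1 and its gap to compound 3 both lie beyond the scatter. Compound 4 `O=C(O)CCc1ccc(C#Cc2ccccn2)cc1` differs from compound 2 in one place: hydrogen in place of nitro on an aromatic carbon. Among the compounds with values here, no step between two measured compounds covers this change, so its size is uncertain. A rise is expected, because compound 1 at 110% and compound 3 at 125% carry no nitro group and sit higher than compound 2. Compound 4 is expected to reach about 105%, within 85% to 125%. The expected step is a number 18 percentage points higher from compound 2 to compound 4 (beyond the scatter).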

Compound 4, largest response reached (reported as efficacy), in percent of the reference or control that the assay uses: 98%
Beside the measured number, compound 4's estimate is 7 percentage points above it; low and high end bracket the measured number.
By their numbers in this assay, from the lowest: compound 2; then compound 4; then compound 1; then compound 3.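

Hydrogen in place of nitro on this aromatic carbon, ortho to a large group and two atoms from the ring nitrogen, gives in this assay a modest rise of a number 11 percentage points higher from compound 2 to compound 4 (beyond the scatter) in this series. The nitro group is therefore not required for a full response at this position on this core. Nothing on hand explains the step.

Going by these compounds, whether an amine or a methoxy group on the same carbon would go beyond compound 4 stays open. So does whether the same change gives a similar step on other cores.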